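Azide to Benzamide: What Liver Microsome Stability May Show

The source may report more compounds than this note shows. Statements on the series, on what has been measured and on what is new or still open speak of the compounds shown alone.

Among the measured compounds shown here, compound 1 `NS(=O)(=O)c1cc(-c2nnc(CN3CCN(c4ccc(Cl)cc4)CC3)o2)c(Cl)cc1SCc1ccccc1` is one of two compounds measured so far; in an ADME assay on microsomes from liver (Homo sapiens) for metabolic stability, read by LC-MS, using NADPH, tested at 5 uM (a lower number here means that the compound disappears faster, a higher number that the compound lasts longer), compound 1 gives 0.455 h. Compound 2 `[N-]=[N+]=NCc1nnc(-c2cc(S(N)(=O)=O)c(SCc3ccccc3)cc2Cl)o1` shares the same core. In this assay compound 2 gives > 1 h, which is a limit of the assay rather than a number. Compound 2 therefore stands only at the limit of > 1 h in this assay, at which 1 of the 2 values shown sits, and its exact half-life is not known. Compound 3 `NS(=O)(=O)c1cc(-c2nnc(CNC(=O)c3ccccc3)o2)c(Cl)cc1SCc1ccccc1` has not yet been measured. It differs from compound 2 by benzamido in place of azido on a saturated chain carbon bound to an aromatic carbon, bringing in an amide and a six-membered aromatic ring of carbon only. For the measured compounds named here, no step between measured compounds differing in one place is available, so the direction is uncertain; a modest downward move in this assay is expected, since the only full number, from compound 1, is 0.455 h. For compound 3 the half-life is estimated at 0.8 h, ranging from 0.35 h to 2 h. This estimate is expected to mean an at least 1.2-fold lower number from compound 2 to compound 3 (0.09 log units; that floor lies within the scatter).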

Compound 3, half-life: 0.187 h
Compound 3: the middle estimate sits 4.3-fold (0.63 log units) above what was measured; measured number below the stated range.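

Among the compounds shown here, this is the first step that can be read at this position, the saturated chain carbon bound to an aromatic carbon: in this assay, benzamido in place of azido gives an at least 5.3-fold lower number from compound 2 to compound 3 (0.72 log units; beyond the scatter). The group on this carbon can therefore move the half-life beyond the usual scatter, and here the move is towards faster disappearance. The true size of the step may be larger, because compound 2 stands at a limit of the assay rather than at a number: the limit of > 1 h in this assay, at which 1 of the 3 values shown sits.

On these data alone, what remains open is which part of benzamido goes with the shorter half-life, the amide or the six-membered aromatic ring of carbon only. Acetamido on the same carbon, which keeps the amide without that ring, would separate the two.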